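Pyrimidin-5-yl for pyridin-4-yl in a T-type channel series

The source may report more compounds than this note shows. Statements on the series, on what has been measured and on what is new or still open speak of the compounds shown alone.

Of the compounds shown here, two have been measured in an assay on isolated protein for inhibition of Voltage-dependent T-type calcium channel subunit alpha-1G (Homo sapiens), read by patch clamp, tested at 10 uM; a higher number here means more inhibition at the concentration tested (going by the name of the read-out), a lower number less inhibition. Compound 1 `NC(=O)c1cccc(NCc2c[nH]c3ccc(Cl)cc23)c1` gives 39.9% in this assay. Compound 2 `COc1cc(CNCc2ccc(-c3ccncc3)cc2)cc(OC)c1OC` gives 21.9% in this assay, the lower of the two numbers, and the gap to compound 1 lies beyond the usual scatter of repeated measurements. Nothing else is known for this pair; the two compounds share no common core, so their two values simply stand side by side.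

Compound 3 `COc1cc(CNCc2ccc(-c3cncnc3)cc2)cc(OC)c1OC` has not yet been measured. It differs from compound 2 in one place: pyrimidin-5-yl in place of pyridin-4-yl on an aromatic carbon. Among the compounds with values here, no step between measured compounds that differ in a single position is available, so there is no measured change of this kind to lean on. The expectation is that the step of a number 4.9 percentage points lower from compound 2 to compound 3 (within the scatter) will stay within the usual scatter, or at most amount to a modest loss of inhibition. On that basis compound 3 is estimated to give 17% in this assay, with a likely range from 5% to 32%.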

Compound 3, a percentage reported as inhibition, at one concentration (the size of the read-out at that concentration, not a potency): 38.3%
The estimate for compound 3 lay 21.3 percentage points below the measured number; measured number above the stated range.
By their numbers in this assay, from the lowest: compound 2; then compounds 3 and 1 (each within the scatter of the next).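

Within the data shown here, this is the first single-place change in the set, and it shows that the position para to a large group, on the six-membered aromatic ring of carbon only, is not silent in this assay: pyrimidin-5-yl in place of pyridin-4-yl gives a number 16.4 percentage points higher from compound 2 to compound 3 (beyond the scatter). The change keeps the count of six heavy atoms and the absence of net charge, and the entering ring carries 2 hetero atoms and 2 hydrogen-bond acceptors where the leaving ring carries 1 of each, so a swap of one ring carbon for a nitrogen is enough to move the read-out beyond the scatter. No measurement shown here accounts for the size or direction of this step.

A single step cannot separate the effect of the added ring nitrogen from the effect of where the ring nitrogens lie, and a pyridin-3-yl or a plain phenyl group at this place would be needed to tell these apart. From the compounds shown here alone, whether the same exchange would raise inhibition on a different core, such as that of compound 1, also remains open.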